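The source may hold more compounds than are shown below. What is called first, only, known or untested is meant among the compounds shown, and "the series" means these compounds.

Compound 3 `CSCC[C@H](NC(=O)c1ccc(NCc2cncn2Cc2ccc(C#N)cc2)cc1-c1ccccc1)C(=O)O` is the point of departure. In a functional assay on NIH3T3 cells (Mus musculus) (a lower number here means that less compound is needed, a higher number that more compound is needed for the effect), compound 3 gives > 10 uM, which is a limit of the assay and not a number. Two measured neighbours stand beside it. Compound 1 `CSCC[C@H](NC(=O)c1ccc(NCc2cncn2Cc2cccc(C#N)c2)cc1-c1ccccc1)C(=O)O` carries 3-cyanophenyl where compound 3 carries 4-cyanophenyl on a saturated chain carbon bound to an aromatic nitrogen. In this assay compound 1 gives > 10 uM, again a limit. Compound 2 `N#Cc1ccc(Cn2cncc2CNc2ccc(C(=O)NCc3ccccc3)c(-c3ccccc3)c2)cc1` carries benzyl on the amide-type nitrogen in place of 1-carboxy-3-(methylsulfanyl)propyl. In this assay compound 2 gives > 10 uM, also a limit. The two steps onto compound 3, a step that the two limits leave unreadable from compound 1 to compound 3 and a step that the two limits leave unreadable from compound 2 to compound 3, cannot be sized because of the limit of > 10 uM in this assay, at which 3 of the 3 values shown sit.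

Compound 4 `CSCC[C@H](NC(=O)c1ccc(NCc2cncn2Cc2ccc([N+](=O)[O-])cc2)cc1-c1ccccc1)C(=O)O` differs from compound 3 by nitro in place of cyano on an aromatic carbon. Among the measured compounds shown here, neither measured step touches this part of the molecule, and neither can be read in size, so no direction can be drawn from them; with every value so far sitting at the limit, compound 4 is expected to remain there as well. The expected step is a step that the limit leaves unreadable from compound 3 to compound 4. For compound 4 in this assay the estimate is 20 uM, with a range from 5 uM to 80 uM, and the result is most likely to be reported only as a limit.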

Compound 4, concentration for half-maximal effect: > 10 uM
Compound 4: a limit, no number; the forecaster's own chance of this, stated with the estimate: 85%; the middle value is on the limit's open side.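

In this assay compound 4 gives > 10 uM, a limit and not a number. No new step can be read, neither from compound 3 to compound 4 nor from compound 1 to compound 4, because all the values are limits: the limit of > 10 uM in this assay, at which 4 of the 4 values shown sit. The compounds shown leave open whether nitro in place of cyano changes the concentration needed at all.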